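Nitro for Methyl on a Thiophene-Linked Acrylamide Series

A few compounds are considered here, and "the series" means these few. Any claim that something is new, unique, unknown or untested is made for them only; others in the source may bear on it.

The series shares an acrylamide bearing a methyl group, joined through a five-membered heteroaromatic ring to a six-membered aromatic ring. Compound 1 `C/C(=C\c1cc(-c2ccc(C)nc2)co1)C(N)=O` carries a methyl-substituted pyridine. In a functional assay on BGC-823 cells (Homo sapiens) for cytotoxicity, read by CCK-8 assay, with a stated time of 24 h (on this read-out higher numbers stand for weaker inhibition and lower numbers for stronger inhibition), compound 1 returns only the assay limit, > 50000 nM, not a number. Compound 2 `C/C(=C\c1cc(-c2ccc(C)cc2)cs1)C(N)=O` instead carries a methyl-substituted benzene on a thiophene. In this assay compound 2 also reaches only the limit, > 50000 nM, so no number is known for it. Compound 2 therefore stands nowhere above the others: both values shown sit at the limit of > 50000 nM in this assay, at which 2 of the 2 values shown sit, and no ranking between compound 1 and compound 2 can be drawn.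

Compound 3 `C/C(=C\c1cc(-c2ccc([N+](=O)[O-])cc2)cs1)C(N)=O` differs from compound 2 by a single change, (nitro in place of methyl on an aromatic carbon), nitro in place of methyl on an aromatic carbon. For the measured compounds named here, no measured step shows what such a change does, and both measured compounds are at the limit, so there is no anchor for a direction. The step of an at least 1.2-fold lower number from compound 2 to compound 3 (0.09 log units; that floor lies within the scatter) is expected to be small or none beyond the scatter. Compound 3 is estimated at 40000 nM, within a range from 8000 nM to 150000 nM.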

Compound 3, half-maximal inhibitory concentration: > 50000 nM
Compound 3 gave a limit, no number; the forecaster's own chance of this, stated with the estimate: 65%; at least 1.2-fold (0.09 log units) between middle value and limit.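

In this assay compound 3 gives > 50000 nM, which is a limit and not a number. Compound 2 also stands at a limit, so no step can be read between compound 2 and compound 3: the limit of > 50000 nM in this assay, at which 3 of the 3 values shown sit.

The compounds shown leave open whether nitro in place of methyl changes the read-out at all, and how the three compounds rank.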